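Phenyl in place of methyl: expected effect on cytotoxicity

The source may report more compounds than this note shows. Statements on the series, on what has been measured and on what is new or still open speak of the compounds shown alone.

Two compounds of the series are measured in a functional assay on C6 cells (Rattus norvegicus) for cytotoxicity, read by MTT assay, with a stated time of 24 h, tested at 6 ug/mL; on this read-out higher numbers stand for a weaker effect at the one concentration tested and lower numbers for a stronger effect. Compound 1 `Cc1ccc(-c2cs/c(=N/NC(=O)CSc3nnnn3-c3ccccc3)n2-c2ccccc2)cc1` gives 66.8%. Compound 2 `Cn1nnnc1SCC(=O)N/N=c1/scc(-c2ccccc2)n1-c1ccccc1` gives 85.2%, the higher of the two numbers, with a gap to compound 1 that lies beyond the usual scatter. Compound 3 `O=C(CSc1nnnn1-c1ccccc1)N/N=c1/scc(-c2ccccc2)n1-c1ccccc1` differs from compound 2 by phenyl in place of methyl on an aromatic nitrogen. Among the measured compounds shown here, no measured pair isolates this change; compound 1, which also carries 1-phenyl-1H-tetrazol-5-yl, stands at 66.8%. A downward step of moderate size is therefore expected, a number 13.2 percentage points lower from compound 2 to compound 3 (beyond the scatter). Compound 3 is estimated at 72%, within 55% to 90%.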

Compound 3, a percentage reported as activity, at one concentration (the size of the read-out at that concentration, not a potency): 52.1%
Estimate against measurement, compound 3: 19.9 percentage points above; the whole stated range lies above it.
By their numbers in this assay, from the lowest: compound 3; then compound 1; then compound 2.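

In this assay, 1-phenyl-1H-tetrazol-5-yl in place of 1-methyl-1H-tetrazol-5-yl now has its own matched pair, and the change gives a stronger effect at the one concentration tested (a number 33.1 percentage points lower from compound 2 to compound 3 (beyond the scatter)). With 1-phenyl-1H-tetrazol-5-yl held fixed, hydrogen in place of methyl on an aromatic carbon also gives a stronger effect (a number 14.7 percentage points lower from compound 1 to compound 3 (beyond the scatter)). No available data explain either step.

Whether an aromatic ring on this nitrogen is required remains open, as neither an ethyl nor a benzyl group stands among the compounds shown. From the compounds shown here alone, how an amine or a carboxylic acid on the phenyl ring would read is also open.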